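A few compounds are considered here, and "the series" means these few. Any claim that something is new, unique, unknown or untested is made for them only; others in the source may bear on it.

- compound 1 `CCC1C(=O)N(C)c2cnc(Nc3ccc(S(=O)(=O)NCC(C)C)cc3)nc2N1c1ccn(C)n1` gives 15000 nM
- compound 2 `CC[C@@H]1C(=O)N(C)c2cnc(-n3ccc4cc(C(=O)NCC(C)C)ccc43)nc2N1C1CCCC1` gives "not active" (no number reported)
- compound 3 `CC[C@@H]1C(=O)N(C)c2cnc(-n3ccc4cc(C(=O)NC5CCCC5)ccc43)nc2N1C1CCCC1` gives 856 nM

All three results come from a functional assay on NCI-H1975 cells (Homo sapiens) for antiproliferative activity, read by CCK-8 assay, with a stated time of 72 h (on this read-out higher numbers stand for weaker inhibition of growth and lower numbers for stronger inhibition of growth), and only two of them are actual numbers. Compound 1, at 15000 nM in this test, holds the higher of those two, so it sits at the weak end of the growth-inhibition scale. Compound 3 holds the lower number, and compound 2 has none.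

Compound 4 `CCC1C(=O)N(C)c2cnc(Nc3ccc(S(=O)(=O)NCCCO)cc3)nc2N1c1ccn(C)n1` has not yet been measured. It keeps the core of compound 1 and carries 2-hydroxyethyl in place of isopropyl on a saturated chain carbon bound to a sulfonamide nitrogen. Cut one bond further out, this reads isobutyl to 3-hydroxypropyl.

For the measured compounds named here, no pair of measured compounds shows this swap on its own, so the expectation rests on compound 1 at 15000 nM and on the change itself. In this assay no step beyond the scatter is expected, in either direction. The expected step is a 1.1-fold lower number from compound 1 to compound 4 (0.03 log units; within the scatter) and it is only a rough guess. For compound 4 the estimated value is 14000 nM within an expected range of 5000 nM to 40000 nM in this test.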

Compound 4, concentration for 50% growth inhibition: 25800 nM
The estimate for compound 4 lay 1.8-fold (0.27 log units) below the measured number, and the stated range covers the measured number.
By their numbers in this assay, from the lowest: compound 3; then compounds 1 and 4 (each within the scatter of the next).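

In this assay, putting 2-hydroxyethyl in place of isopropyl on a saturated chain carbon bound to a sulfonamide nitrogen gives a 1.7-fold higher number from compound 1 to compound 4 (0.24 log units; within the scatter), so the two compounds cannot be told apart. For the compounds shown here, this is the first direct look at this position: on the core of compound 1, a chain carrying one hydrogen-bond donor and one hydrogen-bond acceptor reads the same as an isobutyl chain that carries neither. Nothing measured here bears on why the swap gives this result.

The compounds shown leave open whether an amine, a carboxylic acid or a longer chain in place of isobutyl would produce a step beyond the scatter. This single pair also cannot show whether the same swap would read alike on a different core.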